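Methylating the amide nitrogen of compound 3

The source may hold more compounds than are shown below. What is called first, only, known or untested is meant among the compounds shown, and "the series" means these compounds.

Measured compounds:
compound 1 `CCN(C(=O)c1cc(C)ccc1-n1nccn1)[C@@H](C)Cn1ccc(-c2ccc(F)cn2)n1`: 1.62 nM
compound 2 `CCN(C(=O)c1cc(C)ccc1-n1nccn1)[C@H](C)Cn1ccc(-c2ccc(F)cn2)n1`: 86.6 nM
compound 3 `Cc1ccc(-n2nccn2)c(C(=O)N[C@@H](C)Cn2cc(-c3ccc(F)cn3)cn2)c1`: 245 nM

In a functional assay on cells for antagonist activity at Orexin/Hypocretin receptor type 1 (Homo sapiens), read by fluorescence and calcium flux, with a stated time of 30 min (on this read-out lower numbers stand for stronger inhibition and higher numbers for weaker inhibition), compound 3 gives the highest number of the three, with compound 2 nearest and compound 1 furthest away. Within the data shown here, the one step that joins two measured compounds, a 53-fold higher number from compound 1 to compound 2 (1.73 log units; beyond the scatter), rests on the fact that compounds 1 and 2 differ only in the configuration as drawn and concerns configuration alone.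

Compound 4 `Cc1ccc(-n2nccn2)c(C(=O)N(C)[C@@H](C)Cn2cc(-c3ccc(F)cn3)cn2)c1` is compound 3 with methyl in place of hydrogen on an amide-type nitrogen. Among the measured compounds shown here, no measured step bears on this change: compounds 1 and 3 both carry an alkyl-bearing or hydrogen-bearing amide nitrogen, but they differ in more than one place, so only their values can be set side by side, and those show compound 1 far below compound 3 in this assay. The step from configuration inversion gives no guide to a methyl entering an amide nitrogen, so the direction of the step is taken from the standing of the tertiary amide compound 1 against the secondary amide compound 3, with wide uncertainty.

Compound 4 is therefore expected to give a lower number than compound 3, with an estimated step of an 8.2-fold lower number from compound 3 to compound 4 (0.91 log units; beyond the scatter). For compound 4 the estimate is 30 nM, with a range from 6 nM to 150 nM.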

Compound 4, half-maximal inhibitory concentration: 4.39 nM
Estimate against measurement, compound 4: 6.8-fold (0.83 log units) above; measured number below the stated range.
By their numbers in this assay, from the lowest: compound 1; then compound 4; then compound 2; then compound 3.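

In this assay, among these compounds, methyl in place of hydrogen on an amide-type nitrogen gives a 56-fold lower number from compound 3 to compound 4 (1.75 log units; beyond the scatter), the first measured step at this position. Among the compounds shown here, the only step known before it was a 53-fold higher number from compound 1 to compound 2 (1.73 log units; beyond the scatter), which concerned configuration alone, so the result shows that a change of a single carbon on the amide nitrogen, with the configuration as drawn unchanged, can shift the number in this assay by a similar amount. Nothing in the available evidence bears on why the methyl has so large an effect, and the configuration result offers no explanation for it.

The compounds shown leave open how the number responds to other groups on this nitrogen, such as a longer chain like propyl or a ring like cyclopropyl, and compound 1 cannot settle the matter, since it differs from compound 4 in more than one place. They also leave open whether the opposite configuration of compound 4 would cost as much as the configuration step seen with compound 1 and compound 2.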